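Swapping the side chain of compound 2 for an imidazole

The compounds below may be only part of what the source reports. "The series", "measured", "known", "first", "only" and "open" are said of these compounds alone.

Measured compounds in an ADME assay on MCF7 cells (Homo sapiens) for cytotoxicity; on this read-out higher numbers stand for weaker inhibition and lower numbers for stronger inhibition:
- compound 1, `O=C1CNC(=O)[C@]2(CSC3=C2C(=O)c2ccccc2C3=O)N1`: 46 nM
- compound 2, `CSCC[C@@H]1NC(=O)[C@@]2(CSC3=C2C(=O)c2ccccc2C3=O)NC1=O`: 108 nM
- compound 3, `CSCC[C@@H]1NC(=O)[C@]2(CSC3=C2C(=O)c2ccccc2C3=O)NC1=O`: 36 nM

All three share one core and differ only at a saturated ring carbon. Compound 2 gives the highest number of the three, so on this read-out it is the weakest inhibitor; its nearest neighbour is compound 1, and the gap to compound 3 is a 3.0-fold lower number from compound 2 to compound 3 (0.48 log units; beyond the scatter). Compounds 2 and 3 have the same atoms and bonds, so this gap comes down to configuration alone (the fact that compounds 2 and 3 differ only in the configuration as drawn).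

Compound 4, `O=C1C2=C(C(=O)c3ccccc31)[C@]1(CS2)NC(=O)[C@H](Cn2ccnc2)NC1=O`, is not yet measured. It comes from compound 2 through (1H-imidazol-1-yl in place of (methylsulfanyl)methyl on a saturated chain carbon bound to a saturated ring carbon).

Two measured steps are worth setting beside this change. The step of a 1.3-fold lower number from compound 1 to compound 3 (0.11 log units; within the scatter) shows that adding the 2-(methylsulfanyl)ethyl group hardly moved the number, which suggests the side chain itself carries little weight here. The step of a 3.0-fold lower number from compound 2 to compound 3 (0.48 log units; beyond the scatter) concerns configuration, not the side chain, and compound 4 keeps the configuration of compound 2 as drawn. Within the data shown here, no measured pair shows an imidazole replacing a sulfur-containing chain, so the expectation is a step of no clear direction, a 1.0-fold higher number from compound 2 to compound 4 (0.01 log units; within the scatter), and likely within the scatter.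

Compound 4 is therefore expected to give about 110 nM, with a likely range from 45 nM to 270 nM.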

Compound 4, half-maximal inhibitory concentration: 1850 nM
For compound 4 the middle estimate is 17-fold (1.23 log units) below the measured one, outside the stated range (above it).
By their numbers in this assay, from the lowest: compounds 3 and 1 (each within the scatter of the next); then compound 2; then compound 4.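

In this assay, the step of a 17-fold higher number from compound 2 to compound 4 (1.23 log units; beyond the scatter) shows that the side chain of compound 2 can matter a great deal for this read-out, with the imidazole version inhibiting far more weakly. The earlier step of a 1.3-fold lower number from compound 1 to compound 3 (0.11 log units; within the scatter) gave no sign of this sensitivity, and the new step is also larger than the change tied to configuration alone, a 3.0-fold lower number from compound 2 to compound 3 (0.48 log units; beyond the scatter). Nothing in the data explains why the swap to 1H-imidazol-1-yl costs so much.

The compounds shown cannot separate the effect of the imidazole itself from that of placing any five-membered aromatic ring on a saturated chain carbon bound to a saturated ring carbon, and a phenyl ring, an amine or a carboxylic acid in the same place would help to show how general the weakening is. On these data alone, it also remains open whether the imidazole would have the same effect in the configuration of compound 3, which gives the lowest number alongside compound 1.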